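This account rests on a few compounds, and the source may have more. Where it says the series, first, only, none or still open, it means among the compounds named here.

Working notes on the series. Compound 1 `CN(Cc1ccc2nccn2c1)c1nnc(-c2ccc(C3CC3)cc2)o1` gives 20000 nM in an assay on isolated protein for inhibition of tyrosine-protein kinase receptor UFO (Homo sapiens), read by LC-MS; a higher number here means a weaker inhibitor, a lower number a stronger inhibitor. Compound 2 `COc1ccccc1-c1ccc(-c2nnc(N(C)Cc3ccc4nccn4c3)o2)cc1` gives 1580 nM in this assay, and compound 3 `Cc1nn(C)c(C)c1-c1ccc(-c2nnc(N(C)Cc3ccc4nccn4c3)o2)cc1` gives 1260 nM. The two replacements of cyclopropyl bring the large steps of a 13-fold lower number from compound 1 to compound 2 (1.10 log units; beyond the scatter) and a 16-fold lower number from compound 1 to compound 3 (1.20 log units; beyond the scatter); the exchange of the two aryl groups against each other brings only a 1.3-fold lower number from compound 2 to compound 3 (0.10 log units; within the scatter), so compounds 2 and 3 cannot be told apart. Compound 3 holds the lowest number of the three, but only its gap to compound 1 lies beyond the scatter.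

Compound 4 `Cc1cc(-c2c(C)nn(C)c2C)ccc1-c1nnc(N(C)Cc2ccc3nccn3c2)o1` differs from compound 3 by methyl in place of hydrogen on an aromatic carbon. Within the data shown here, none of the measured steps touches this kind of change: all three concern the group that stands in place of cyclopropyl, and the two large ones, a 13-fold lower number from compound 1 to compound 2 (1.10 log units; beyond the scatter) and a 16-fold lower number from compound 1 to compound 3 (1.20 log units; beyond the scatter), both remove cyclopropyl. Among the measured compounds shown here, for a methyl entering a six-membered aromatic ring of carbon only, ortho to a large group, the series holds no precedent. With nothing pointing either way, no step beyond the scatter is expected in this assay. Compound 4 is therefore estimated at 1260 nM, in the range 400 nM to 4000 nM. This corresponds to an expected step of no change at the digits printed from compound 3 to compound 4 (within the scatter).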

Compound 4, half-maximal inhibitory concentration: 79.4 nM
Estimate against measurement, compound 4: 16-fold (1.20 log units) above; measured number below the stated range.
By their numbers in this assay, from the lowest: compound 4; then compounds 3 and 2 (each within the scatter of the next); then compound 1.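

In this assay, a single methyl in place of hydrogen on an aromatic carbon of the six-membered aromatic ring of carbon only, ortho to a large group and meta to the 1,3,5-trimethyl-1H-pyrazol-4-yl group, brings a 16-fold lower number from compound 3 to compound 4 (1.20 log units; beyond the scatter) and so lies well beyond what the series had shown for this place. Every earlier step concerned the group standing in place of cyclopropyl, whereas this one shows that the ring carrying that group also responds, and that an entering group of just 1 heavy atom is enough for a large step. No measurement shown accounts for this step.

The compounds shown leave open whether ethyl, methoxy, chlorine or an amine at this same place would give a similar step, and whether methyl elsewhere on this ring would do so. From the compounds shown here alone, it also remains open whether the same methyl would bring a comparable step with 2-methoxyphenyl, as in compound 2, in place of the 1,3,5-trimethyl-1H-pyrazol-4-yl group.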